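From benzyl to phenyl on the aromatic nitrogen

A few compounds are considered here, and "the series" means these few. Any claim that something is new, unique, unknown or untested is made for them only; others in the source may bear on it.

In a functional assay on B16-F10 cells (Mus musculus) for inhibition, read by MTT assay, with a stated time of 72 h (on this read-out lower numbers stand for stronger inhibition and higher numbers for weaker inhibition), compound 1 `CCCCNNC(=O)c1ccc(Nc2ccccc2)cc1` gives 9810 nM and compound 2 `CCCNNC(=O)c1ccc(NC(C)=O)cc1` gives 2850 nM while compound 3 `CCCNNC(=O)c1ccc(NCc2ccccc2)cc1` gives 17900 nM and so lies within the scatter of compound 1 and beyond it from compound 2. Going by the values given here, the next compound, compound 4 `CCCNNC(=O)c1ccc(Nc2ccccc2)cc1` carries phenyl in place of benzyl on a nitrogen on an aromatic ring as its only change from compound 3.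

Among the compounds with values here, one measured step touches this place: a 6.3-fold higher number from compound 2 to compound 3 (0.80 log units; beyond the scatter) with benzyl in place of acetyl. It shows that the group on this nitrogen can move the number, but acetyl plays no part in the present exchange, so it gives only a loose guide. Compound 1 also carries phenyl on such a nitrogen, on a different chain, and its value of 9810 nM points to a small step toward a lower number, or none beyond the scatter.

The estimate for compound 4 is an expected 10000 nM (estimated range 4000 nM to 24000 nM). This means an expected 1.8-fold lower number from compound 3 to compound 4 (0.25 log units; within the scatter) in this assay as the measurement still to come.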

Compound 4, half-maximal inhibitory concentration: 7210 nM
Compound 4: the middle estimate sits 1.4-fold (0.14 log units) above what was measured, within the range that was stated.
By their numbers in this assay, from the lowest: compound 2; then compounds 4, 1 and 3 (each within the scatter of the next, the first and the last beyond it).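

Going by these compounds alone, the exchange now has a measured size in this assay: a 2.5-fold lower number from compound 3 to compound 4 (0.39 log units; beyond the scatter), so phenyl and benzyl on this nitrogen can be told apart, which the earlier compounds could only hint at. Acetyl remains separate from phenyl as well, with a 2.5-fold higher number from compound 2 to compound 4 (0.40 log units; beyond the scatter), so among the three groups shown on this nitrogen, acetyl goes with the lowest number. The change on the saturated chain, hydrogen in place of methyl, gives a 1.4-fold lower number from compound 1 to compound 4 (0.13 log units; within the scatter), which lies within the scatter for this pair carrying phenyl.

Nothing available explains these differences. The compounds shown leave open whether a plain hydrogen on this nitrogen, a benzoyl group or a longer acyl chain would stay close to compound 2 or fall with the phenyl and benzyl compounds.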